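Series notes: removal of the (tert-butoxycarbonyl)amino group

The compounds below may be only part of what the source reports. "The series", "measured", "known", "first", "only" and "open" are said of these compounds alone.

Measured so far:
Compound 1 `CC(C)(C)OC(=O)NC1CCCN(C(=O)CN2CN(c3ccccc3)C3(CCN(C(=O)c4ccc(C5CCCCC5)cc4)CC3)C2=O)C1`, an assay on HEK293 cells for displacement of a labelled ligand from NPC1-like intracellular cholesterol transporter 1 (Homo sapiens) (on this read-out higher numbers stand for weaker inhibition and lower numbers for stronger inhibition), 4400 nM
Compound 2 `CCC1CCCN(C(=O)CN2CN(c3ccccc3)C3(CCN(C(=O)c4ccc(C(C)(C)C)cc4)CC3)C2=O)C1`, this assay 3900 nM
Compound 3 `CCc1nn(CC)c(C2CCN(C(=O)CN3CN(c4ccccc4)C4(CCN(C(=O)c5ccc(C(C)(C)C)cc5)CC4)C3=O)CC2)c1CC`, this assay 4600 nM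

The three measured compounds share one core and sit close together on this read-out. Compound 1 gives the second highest of the three numbers; its nearest neighbour is compound 3, and its furthest is compound 2, and both of those gaps lie within the usual scatter, so no order among the three can be stated. Going by the values given here, none of the three differ from each other in a single place, so no isolated step has been measured.

Compound 4 `O=C(CN1CN(c2ccccc2)C2(CCN(C(=O)c3ccc(C4CCCCC4)cc3)CC2)C1=O)N1CCCCC1` is the next compound to be measured in this assay. It differs from compound 1 in one place: hydrogen in place of (tert-butoxycarbonyl)amino on a saturated ring carbon. The (tert-butoxycarbonyl)amino group leaves and hydrogen enters on the saturated ring carbon of the six-membered non-aromatic ring with one nitrogen.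

Since compound 2 and compound 3, carrying quite different groups at that part of the molecule, return numbers indistinguishable from compound 1, the expectation for compound 4 is a step of a 1.1-fold higher number from compound 1 to compound 4 (0.06 log units; within the scatter), that is no change beyond the scatter. Compound 4 is estimated at 5000 nM, with a range from 2000 nM to 12000 nM.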

Compound 4, half-maximal inhibitory concentration: 1100 nM
The estimate for compound 4 lay 4.5-fold (0.66 log units) above the measured number; measured number below the stated range.
By their numbers in this assay, from the lowest: compound 4; then compounds 2, 1 and 3 (each within the scatter of the next).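

In this assay, the saturated ring carbon two ring bonds from the ring nitrogen is not indifferent to what it carries: hydrogen in place of (tert-butoxycarbonyl)amino gives a 4.0-fold lower number from compound 1 to compound 4 (0.60 log units; beyond the scatter), a modest step beyond the scatter. The earlier compounds shown here could not show this: no two of them differed in a single place, and their closeness said nothing about any one group at this carbon. On the core of compound 1, the (tert-butoxycarbonyl)amino group is therefore not neutral on this read-out.

No measurement bears on why the number falls with this change. Also open, on these data alone, is whether a free amine or a methyl group on this carbon would stay with compound 4 or return towards compound 1.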